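The compounds below may be only part of what the source reports. "The series", "measured", "known", "first", "only" and "open" are said of these compounds alone.

Among the measured compounds shown here, in a physicochemical assay for solubility, at pH 6.8 (a higher number here means a more soluble compound, a lower number a less soluble compound), compound 1 `Cc1c(COc2cccc(OCC3CCOCC3)c2)[nH]c2ccccc2c1=O` gives 5000 nM, and compound 2 `O=c1c(Cl)c(COc2cccc(OCC3CCOCC3)c2)[nH]c2ccccc12` gives 2000 nM, the lower of the two numbers measured so far. Compound 3 `CC(C)c1c(COc2cccc(OCC3CCOCC3)c2)[nH]c2ccccc2c1=O` has not yet been measured. It differs from compound 2 at a single place, with isopropyl in place of chloro on an aromatic carbon. For the measured compounds named here, only one measured step bears on this change, a 2.5-fold lower number from compound 1 to compound 2 (0.40 log units; beyond the scatter), a modest step beyond the scatter, in which chloro replaced methyl at that same place. It involves a different pair of groups, so it offers only a rough guide to size and no firm direction for isopropyl. In this assay, the expected change is a 1.3-fold higher number from compound 2 to compound 3 (0.10 log units; within the scatter), which would stay within the scatter. Compound 3 is estimated at 2500 nM, with an expected range from 800 nM to 8000 nM.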

Compound 3, solubility: 3000 nM
For compound 3 the middle estimate is 1.2-fold (0.08 log units) below the measured one, and the stated range covers the measured number.
By their numbers in this assay, from the lowest: compounds 2, 3 and 1 (each within the scatter of the next, the first and the last beyond it).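

Read in this assay, the new group gives a 1.5-fold higher number from compound 2 to compound 3 (0.18 log units; within the scatter), and against the methyl group it gives a 1.7-fold lower number from compound 1 to compound 3 (0.22 log units; within the scatter). So a group of three heavy atoms at this aromatic carbon lands within the scatter of both the chloro compound and the methyl compound, even though those two lie beyond the scatter of each other, and the size of the group alone does not set the number across these three compounds. Nothing available gives a reason for these numbers.

Going by these compounds, how the number responds to a different kind of group at this carbon stays open, such as an amine, a carboxylic acid or a longer chain. Also open, on these data alone, is whether these small steps would hold on a core changed elsewhere, for example with a different group in place of the tetrahydropyranyl-free ether side chain.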